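The compounds below may be only part of what the source reports. "The series", "measured", "known", "first", "only" and "open" are said of these compounds alone.

Compound 1 `CNC(=O)c1sc(-c2ccc(Cl)cc2)nc1C(Br)Br` in an ADME assay on BHK15 cells (Mesocricetus auratus) for inhibition, read by XTT assay, with a stated time of 36 h (a higher number here means a weaker inhibitor of growth, a lower number a stronger inhibitor of growth), gives 74600 nM. Compound 2 `CCNC(=O)c1sc(-c2ccc(Cl)cc2)nc1C(Br)Br` in this assay gives 33300 nM. Among the measured compounds shown here, the step of a 2.2-fold lower number from compound 1 to compound 2 (0.35 log units; beyond the scatter) goes with the change (methyl in place of hydrogen on a saturated chain carbon bound to an amide-type nitrogen), and within this pair it is the only change whose size is known.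

Compound 3 `CCc1nc(-c2ccc(Cl)cc2)sc1C(=O)OC` in this assay gives "not determined" (no result reported), so no number stands for it there; the difference between its core and the core of compound 1 is not broken down here. Compound 4 `COC(=O)c1sc(-c2ccc(Cl)cc2)nc1C(C)C` is to be measured in this assay and differs from compound 3 by methyl in place of hydrogen on a saturated chain carbon bound to an aromatic carbon and a saturated chain carbon. This is the same kind of change as that from compound 1 to compound 2, not the same: there the methyl enters on a saturated chain carbon bound to an amide-type nitrogen, here on a saturated chain carbon bound to an aromatic carbon and a saturated chain carbon.

For the measured compounds named here, with no number for compound 3, the step from compound 3 to compound 4 cannot be anchored; the only guide is that compounds 1 and 2 are both weak growth inhibitors, and a modest step is expected at most. Compound 4 is estimated at 40000 nM in this assay, expected between 8000 nM and 200000 nM.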

Compound 4, concentration for 50% growth inhibition: 49600 nM
Compound 4: middle estimate off by 1.2-fold (0.09 log units), on the low side; measured number inside the range.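

In this assay, among the compounds shown here, compound 3 stands without a number, so no step to compound 4 can be read, and the result for compound 4 remains a single value. The compounds shown leave open what the change from ethyl to isopropyl does to growth inhibition in this assay. No measured evidence bears on this result.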